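Removing a Protecting Group from the Compound with the Highest Number

The source may report more compounds than this note shows. Statements on the series, on what has been measured and on what is new or still open speak of the compounds shown alone.

Measured so far:
compound 1 `NCCCCCNC1=Nc2ccccc2C(CC(=O)NCc2ccccc2)N1c1ccc(-c2ccccc2)cc1` — 8.3%
compound 2 `NCCCCCN1C(Nc2ccc(-c3ccccc3)cc2)=Nc2ccccc2C1CC(=O)NCc1ccccc1` — 15.2%
compound 3 `COC(=O)CC1c2ccccc2N=C(Nc2ccc(-c3ccccc3)cc2)N1CCCCCNC(=O)OC(C)(C)C` — 94.9%

All three were tested in an assay on HEK293 cells for inhibition of Voltage-dependent N-type calcium channel subunit alpha-1B (Homo sapiens), tested at 10 uM; on this read-out higher numbers stand for more inhibition at the one concentration tested (going by the name of the read-out) and lower numbers for less inhibition. Compound 3 stands highest of the three numbers; compound 2 is nearest, its number lower by a gap beyond the usual scatter, and compound 1 is furthest, also beyond the scatter. Compounds 1 and 2 differ from compound 3 in more than one place, so their distance from it cannot be tied to any single change.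

Compound 4 `COC(=O)CC1c2ccccc2N=C(Nc2ccc(-c3ccccc3)cc2)N1CCCCCN` has not yet been measured. It differs from compound 3 in one place: hydrogen in place of tert-butoxycarbonyl on an amine nitrogen. Within the data shown here, no measured pair differs by this change alone, so the step has to be judged from the whole picture. The two compounds carrying the free amine, compound 1 and compound 2, both give low numbers in this assay. A large downward step is therefore expected, well beyond the scatter. In this assay compound 4 is expected to give 30%, within a range from 5% to 70%. That estimate means an expected step of a number 64.9 percentage points lower from compound 3 to compound 4 (beyond the scatter).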

Compound 4, a percentage reported as inhibition, at one concentration (the size of the read-out at that concentration, not a potency): 7.5%
Beside the measured number, compound 4's estimate is 22.5 percentage points above it, and the stated range covers the measured number.
By their numbers in this assay, from the lowest: compounds 4, 1 and 2 (each within the scatter of the next); then compound 3.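

In this assay, among these compounds, replacing tert-butoxycarbonyl with hydrogen on the amine nitrogen gives a number 87.4 percentage points lower from compound 3 to compound 4 (beyond the scatter), the first single change in this set tied to a large loss of inhibition. With the free amine in place, methoxy in place of benzylamino on a carbonyl carbon gives a number 7.7 percentage points lower from compound 2 to compound 4 (within the scatter), so this second change cannot be told from repeat-measurement noise here. No supporting data explain why the tert-butoxycarbonyl change has so large an effect.

On these data alone, it remains open whether another group on that nitrogen, such as acetyl or benzyl, would give a high number like that of compound 3. As far as these compounds go, it is also open whether benzylamino on the carbonyl carbon would keep that number with tert-butoxycarbonyl present.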